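Notes on the amide nitrogen substituent series

A few compounds are considered here, and "the series" means these few. Any claim that something is new, unique, unknown or untested is made for them only; others in the source may bear on it.

Compound 1 `Cc1c(C(C)C)c(=O)on1C(=O)N(C)CCC#N` and compound 2 `Cc1c(C(C)C)c(=O)on1C(=O)N(C)CC(N)=O` share one core and differ only on the chain attached to the amide-type nitrogen. In an assay (strain Wistar) for inhibition of Hormone-sensitive lipase (Rattus norvegicus), read by spectrophotometry (a lower number here means a stronger inhibitor, a higher number a weaker inhibitor), compound 1 gives > 1000 nM, which is a limit of the assay and not a number. In this assay compound 2 gives > 1000 nM, likewise a limit of the assay. The step that the two limits leave unreadable from compound 1 to compound 2 is therefore unreadable, and compound 2 stands only at the limit of > 1000 nM in this assay, at which 2 of the 2 values shown sit. Compound 3 `Cc1c(C(C)C)c(=O)on1C(=O)N(C)c1ccccn1` differs from compound 2 by pyridin-2-yl in place of carbamoylmethyl on an amide-type nitrogen. For the measured compounds named here, no measured step bears on exchanging a chain for an aromatic ring on this nitrogen, as the single step in hand is itself unreadable; no direction can be expected beyond the scatter, and a further limit is the most likely outcome. Compound 3 is expected at 1500 nM, within 300 nM to 10000 nM. The estimated step that the limit leaves unreadable from compound 2 to compound 3 reflects this.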

Compound 3, half-maximal inhibitory concentration: 240 nM
Beside the measured number, compound 3's estimate is 6.3-fold (0.80 log units) above it; the whole stated range lies above it.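

Pyridin-2-yl in place of carbamoylmethyl gives an at least 4.1-fold lower number from compound 2 to compound 3 (0.61 log units; beyond the scatter), and pyridin-2-yl in place of 2-cyanoethyl gives an at least 4.1-fold lower number from compound 1 to compound 3 (0.61 log units; beyond the scatter). For the compounds shown here, these are the first readable steps at this amide-type nitrogen in this assay, and they show that the group on it can move the result beyond the scatter, with both sizes standing as lower bounds. The step between the two chains still cannot be read, and the readable signal rests on compound 3 alone, with the two chain compounds remaining at a limit: the limit of > 1000 nM in this assay, at which 2 of the 3 values shown sit.

The compounds shown leave open whether the aromatic ring or its ring nitrogen carries the change, a question that a phenyl group on this nitrogen would address. From the compounds shown here alone, how a benzyl group or a longer chain ending in an amine would compare also remains open.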